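Pyridin-4-yl for Thiophen-2-yl: an Untested Step

The source may report more compounds than this note shows. Statements on the series, on what has been measured and on what is new or still open speak of the compounds shown alone.

Of the compounds shown here, three built on one shared core have been tested in an assay on isolated protein for inhibition of DNA topoisomerase 1 (Homo sapiens), with a stated time of 30 min, tested at 100 uM; a lower number here means a weaker effect, a higher number a stronger effect of the compound at the concentration tested. Compound 1 `Oc1cccc(-c2cc(-c3ccc(Cl)cc3)nc(-c3cccs3)c2)c1` gives 15.1%, the second highest of the three numbers. Compound 2 `Oc1ccc(-c2cc(-c3ccc(Cl)cc3)nc(-c3cccs3)c2)cc1` gives 38.8%, and compound 3 `Oc1cccc(-c2cc(-c3cccs3)nc(-c3ccccc3Cl)c2)c1` gives 2.7%. The steps between them are modest but beyond the scatter: a number 23.7 percentage points higher from compound 1 to compound 2 (beyond the scatter), and a number 12.4 percentage points lower from compound 1 to compound 3 (beyond the scatter). Both steps move a single substituent around one of the outer phenyl rings; neither touches the thiophen-2-yl group.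

Compound 4 `Oc1cccc(-c2cc(-c3ccncc3)nc(-c3ccc(Cl)cc3)c2)c1` has not been measured. It differs from compound 1 in one place: pyridin-4-yl in place of thiophen-2-yl on an aromatic carbon. Among the measured compounds shown here, no measured step alters this group, so the two known steps do not bear on it directly; they show only that single changes on this core have shifted the read-out by modest amounts in either direction. With nothing pointing up or down, the step is expected to stay within or close to the scatter, and a number 1.1 percentage points lower from compound 1 to compound 4 (within the scatter) is the estimated change. Compound 4 is therefore expected to give 14%, with a range from 2% to 32%.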

Compound 4, a percentage reported as inhibition, at one concentration (the size of the read-out at that concentration, not a potency): 8%
Beside the measured number, compound 4's estimate is 6 percentage points above it, within the range that was stated.
By their numbers in this assay, from the lowest: compounds 3, 4 and 1 (each within the scatter of the next, the first and the last beyond it); then compound 2.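

Among the compounds shown here, this step is the first to touch the group on the aromatic carbon next to the ring nitrogen, which the earlier steps left unchanged. In this assay, replacing thiophen-2-yl with pyridin-4-yl gives a number 7.1 percentage points lower from compound 1 to compound 4 (within the scatter), so this assay does not separate these two groups on the core of compound 1, even though a five-membered aromatic ring containing sulfur gives way to a six-membered aromatic ring containing nitrogen. No accompanying measurement bears on why the result came out this way.

As far as these compounds go, one replacement says little about the position as a whole, so it remains open whether a plain phenyl ring, a morpholine ring or a group carrying a carboxylic acid here would give a step beyond the scatter. From the compounds shown here alone, it is also open whether the same exchange would behave in the same way on compound 2, which gives 38.8% and carries a 4-hydroxyphenyl group in place of the 3-hydroxyphenyl group of compound 1.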